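This account rests on a few compounds, and the source may have more. Where it says the series, first, only, none or still open, it means among the compounds named here.

Of the compounds shown here, three built on a shared core have been tested in a functional assay on CCRF-CEM cells (Homo sapiens) for inhibition, read by cell counting, with a stated time of 72 h; on this read-out higher numbers stand for weaker inhibition and lower numbers for stronger inhibition. Compound 1 `CCN(CC)CN1C(=O)/C(=N/NC(N)=S)c2cc(Cl)ccc21` gives 71000 nM in this assay. Compound 2 `CCN(CC)CN1C(=O)/C(=N/NC(=S)Nc2ccc(C)cc2)c2ccccc21` gives 12000 nM. Compound 3 `CCN(CC)CN1C(=O)/C(=N/NC(=S)Nc2ccc(C)cc2)c2cc(Cl)ccc21` gives 4600 nM. Compound 3 and compound 2 differ by hydrogen in place of chloro on an aromatic carbon, which yields a 2.6-fold lower number from compound 2 to compound 3 (0.42 log units; beyond the scatter). Compound 3 and compound 1 differ by hydrogen in place of 4-methylphenyl on an amide-type nitrogen, a change that yields a 15-fold higher number from compound 3 to compound 1 (1.19 log units; beyond the scatter).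

Compound 4 `CCN(CC)CN1C(=O)/C(=N/NC(N)=S)c2ccccc21` has not yet been measured. It differs from compound 2 by hydrogen in place of 4-methylphenyl on an amide-type nitrogen, the same change as that between compound 3 and compound 1, but made on the core of compound 2. A step of comparable size is expected from compound 2 to compound 4, a 13-fold higher number from compound 2 to compound 4 (1.10 log units; beyond the scatter), because a 15-fold higher number from compound 3 to compound 1 (1.19 log units; beyond the scatter) was observed for the same change. Compound 4 is therefore estimated at 150000 nM, most likely between 50000 nM and 450000 nM.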

Compound 4, half-maximal inhibitory concentration: 164000 nM
The estimate for compound 4 lay 1.1-fold (0.04 log units) below the measured number, and the stated range covers the measured number.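

In this assay, putting hydrogen in place of 4-methylphenyl on the amide-type nitrogen gave a 14-fold higher number from compound 2 to compound 4 (1.14 log units; beyond the scatter) and matched the step already seen on the chlorinated core: the same change on two cores in this assay, a 15-fold higher number (1.19 log units; beyond the scatter) from compound 3 to compound 1 and a 14-fold higher number (1.14 log units; beyond the scatter) from compound 2 to compound 4, 1.1-fold (0.05 log units) apart, within the scatter of two such steps. Putting hydrogen in place of chloro on the aromatic carbon gave a 2.3-fold higher number from compound 1 to compound 4 (0.36 log units; beyond the scatter) and likewise matched its earlier counterpart: the same change on two cores in this assay, a 2.6-fold lower number (0.42 log units; beyond the scatter) from compound 2 to compound 3 and a 2.3-fold lower number (0.36 log units; beyond the scatter) from compound 4 to compound 1, 1.1-fold (0.05 log units) apart, within the scatter of two such steps. Each change therefore carried across the two cores shown with little alteration in size, but these four compounds do not show that this would hold on any other core, nor why the steps agree.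

The compounds shown leave open how a plain phenyl or a longer alkyl chain on that nitrogen would compare. They also leave open whether fluoro or bromo would behave as chloro does.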